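Cyclobutyl Amide on the Shared Benzimidazole-Free Core Description

The compounds below may be only part of what the source reports. "The series", "measured", "known", "first", "only" and "open" are said of these compounds alone.

Of the compounds shown here, three have been measured in an assay on BV-2 cells for positive allosteric modulation of metabotropic glutamate receptor 5 (Mus musculus), read by Griess assay, with stated times of 1 h and 24 h; on this read-out higher numbers stand for weaker inhibition and lower numbers for stronger inhibition. Compound 1 `O=C(Sc1nc2ccccc2[nH]1)c1cccc(Cl)c1` gives 160000 nM. Compound 2 `O=C(Nc1nc2ccccc2[nH]1)c1ccncc1` gives 49000 nM. Compound 3 `O=C(Nc1nc2ccccc2[nH]1)c1cc(Cl)ccc1Cl` gives 12000 nM. On these three numbers compound 2 stands second highest: compound 1 sits a good way higher, beyond the usual scatter, and compound 3 sits a good way lower, also beyond the scatter. Going by the values given here, no pair among the measured compounds differs in only one place, so no single step within the measured set can be read off.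

Compound 4 `O=C(Nc1nc2ccccc2[nH]1)C1CCC1` is the next compound to be tested in this assay . Its change from compound 2 is cyclobutyl in place of pyridin-4-yl on a carbonyl carbon, leaving the shared core and the amide linkage untouched. Nothing in the measured set shows what a saturated carbocycle does here: compound 1 and compound 3 both carry chlorinated benzene rings, and compound 2 carries the pyridin-4-yl that now leaves. The account therefore expects the step from compound 2 to compound 4 to be small, a 1.2-fold higher number from compound 2 to compound 4 (0.09 log units; within the scatter), possibly none beyond the scatter, with a wide band of uncertainty in either direction. For compound 4 in this assay the estimate is 60000 nM, expected to fall between 15000 nM and 250000 nM.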

Compound 4, half-maximal inhibitory concentration: 15000 nM
Beside the measured number, compound 4's estimate is 4.0-fold (0.60 log units) above it, within the range that was stated.
By their numbers in this assay, from the lowest: compounds 3 and 4 (each within the scatter of the next); then compound 2; then compound 1.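

In this assay, the change on the carbonyl carbon gives a 3.3-fold lower number from compound 2 to compound 4 (0.51 log units; beyond the scatter), a modest step, but the first one that can be read at a single place in this series. It shows that this position does not need an aromatic ring to give a lower number: compound 4, with only a saturated four-membered carbocycle there, gives 15000 nM, and that value lies within the scatter of the value of compound 3, which carries a dichlorinated benzene ring on the same amide and gives 12000 nM. No accompanying measurement accounts for the step, so the data show its size and direction but give no reason for it.

The compounds shown leave open whether this result belongs to cyclobutyl in particular or would carry over to cyclopropyl, cyclohexyl or an open chain such as isopropyl. They also leave open how this assay would respond to a hydroxyl group or an amine placed on the cyclobutyl ring, and so whether this saturated group can be built on at all.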